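Chloro to Hydrogen Repeated on a Second Core

The compounds below may be only part of what the source reports. "The series", "measured", "known", "first", "only" and "open" are said of these compounds alone.

Compound 1 `ClCc1ccccc1Cn1cnc2c(Cl)nc(Cl)nc21` was tested in a functional assay on CAKI-1 cells (Homo sapiens) for cytotoxicity, read by sulforhodamine B assay, with a stated time of 48 h (on this read-out higher numbers stand for weaker inhibition of growth and lower numbers for stronger inhibition of growth), and gave 890 nM. Going by the values given here, compound 2 `ClCc1ccccc1Cn1cnc2c(Cl)ncnc21` differs from it by hydrogen in place of chloro on an aromatic carbon and in this assay compound 2 gave 4170 nM; the step of a 4.7-fold higher number from compound 1 to compound 2 (0.67 log units; beyond the scatter) is the only measured pair here that differs in a single place. Compound 3 `ClCc1ccc(Cn2cnc3nc(Cl)nc(Cl)c32)cc1` carries the same atoms as compound 1 joined differently; the difference between the two cores is not broken down here. In this assay compound 3 gave 2750 nM, a number that sits within the scatter of compound 2 and beyond the scatter of compound 1.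

Compound 4 `ClCc1ccc(Cn2cnc3ncnc(Cl)c32)cc1` is related to compound 3 by hydrogen in place of chloro on an aromatic carbon, the same change that separates compound 2 from compound 1, and it is still to be measured in this assay. Among the compounds with values here, the expectation for compound 4 rests on a single earlier case, because the step of a 4.7-fold higher number from compound 1 to compound 2 (0.67 log units; beyond the scatter) is the only measured example of this change; it is therefore taken as the guide, while the different core of compound 3 leaves room for a smaller or larger outcome. Compound 4 is expected to show a step of about a 3.6-fold higher number from compound 3 to compound 4 (0.56 log units; beyond the scatter) from compound 3. The estimate for compound 4 in this assay is 10000 nM, with a range from 4000 nM to 25000 nM.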

Compound 4, concentration for total growth inhibition: 4460 nM
The estimate for compound 4 lay 2.2-fold (0.35 log units) above the measured number; measured number inside the range.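

In this assay, hydrogen in place of chloro on an aromatic carbon gives a 1.6-fold higher number from compound 3 to compound 4 (0.21 log units; within the scatter), so compound 3 and compound 4 cannot be told apart on this read-out, whereas the same change on the core of compound 1 gave a step clearly larger than the scatter. The change therefore does not carry over at a single size from one core to the other in these two pairs, and the difference between the two steps is itself larger than chance scatter would account for: the same change on two cores in this assay, a 4.7-fold higher number (0.67 log units; beyond the scatter) from compound 1 to compound 2 and a 1.6-fold higher number (0.21 log units; within the scatter) from compound 3 to compound 4, 2.9-fold (0.46 log units) apart, beyond the scatter of two such steps

This shows that the size of the step seen on one core was a poor guide to the other, but two pairs set no rule for the series, and nothing here shows which feature of the two cores sets the steps apart.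

The compounds shown leave open how other groups would behave on the aromatic carbon between two ring nitrogen atoms, such as an amine or a methoxy group in place of the chloro, and whether each core would again respond differently. They also leave open whether the remaining chloro group, meta to the changed carbon, would show a similar dependence on the core if it were replaced by hydrogen or an amine.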